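The source may report more compounds than this note shows. Statements on the series, on what has been measured and on what is new or still open speak of the compounds shown alone.

Of the compounds shown here, three built on a shared core have so far been tested. In a functional assay on CCRF-CEM cells (Homo sapiens) for antiproliferative activity, with a stated time of 72 h (on this read-out higher numbers stand for an effect only at larger amounts of compound and lower numbers for an effect already at smaller amounts), compound 3 (`Cc1cn([C@@H]2O[C@H](CO)[C@@H](CO)[C@@H]2O)c(=O)[nH]c1=O`) gives > 100 uM, which is a limit of the assay and not a number. Compound 1 (`Cc1cn([C@@H]2O[C@H](CO)[C@@H](CF)[C@H]2O)c(=O)[nH]c1=O`) gives > 100 uM, again a limit. Compound 2 (`Cc1cn([C@@H]2O[C@H](CO)[C@@H](CN)[C@H]2O)c(=O)[nH]c1=O`) gives > 100 uM, also a limit.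

Compound 4 (`Cc1cn([C@@H]2O[C@H](CO)[C@@H](CO)[C@H]2O)c(=O)[nH]c1=O`) has not yet been measured. It is a close relative of compound 3, and nothing leaves or enters between the two: the two compounds have the same atoms and bonds and differ only in configuration as drawn: 1 of 4 stereo elements differ; a stereocentre at a saturated ring carbon is drawn S in compound 3 and R in compound 4. Only the spatial arrangement at that one ring carbon is different.

Among the measured compounds shown here, the only measured step between two compounds that differ in one place is a step that the two limits leave unreadable from compound 1 to compound 2. It involves a change of group rather than of configuration, so it supplies no size to carry over. For the measured compounds named here, the only guide for compound 1, compound 2 and compound 3 is the limit of > 100 uM in this assay, at which 3 of the 3 values shown sit. No step beyond the usual scatter is therefore expected in this assay, in either direction, and the most likely result is another limit.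

Should a number appear, the estimated move is a step that the limit leaves unreadable from compound 3 to compound 4. For compound 4, the estimated value is 150 uM, with an expected range from 60 uM to 400 uM.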

Compound 4, concentration for half-maximal effect: > 100 uM
Compound 4: a limit, no number (the forecaster's own chance of this, stated with the estimate: 85%); the middle value is on the limit's open side.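

Compound 4 also ends at a limit and not a number, so its steps from compounds 1, 2 and 3 cannot be read in this assay: the limit of > 100 uM in this assay, at which 4 of the 4 values shown sit.

The compounds shown leave open whether the configuration at that ring carbon, or the choice among fluoro, amino and hydroxy on the chain carbon, makes any difference to the antiproliferative effect.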